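The source may report more compounds than this note shows. Statements on the series, on what has been measured and on what is new or still open speak of the compounds shown alone.

In a physicochemical assay, read by HPLC, with a stated time of 3 h, at pH 1.2 (a lower number here means that less of the compound is left, a higher number that more of the compound is left), compound 1 (`CCNC(=O)Nc1sc2ccccc2c1C(=O)N1CCN(C2CCN(C(=O)OC(C)(C)C)CC2)CC1`) gives 23% and compound 2 (`CCNC(=O)Nc1sc2ccccc2c1C(=O)N1CCN(C2CCN(C(=O)OC(C)(C)CF)CC2)CC1`) gives 98% as the higher of the two numbers. Compound 3 (`CCNC(=O)Nc1sc2ccccc2c1C(=O)N1CCN(C2CCN(C(=O)OC(C)(C)C(F)(F)F)CC2)CC1`) is not yet measured: relative to compound 2 it carries trifluoromethyl in place of fluoromethyl on a saturated chain carbon bound to an oxygen next to a carbonyl group and two saturated chain carbons. Going by the values given here, the only measured step bearing on this is a number 75 percentage points higher from compound 1 to compound 2 (beyond the scatter) for fluoro in place of hydrogen on a saturated chain carbon, two bonds along the chain from an oxygen next to a carbonyl group. With compound 2 already at 98% on a read-out of percent remaining, little room is left, so no step beyond the scatter is expected in this assay for this change. The expected step (no change at the digits printed from compound 2 to compound 3 (within the scatter)) is small. Compound 3 is estimated at 98% within a range of 90% to 100% on the same read-out.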

Compound 3, percent of the compound remaining: 100%
Compound 3: the middle estimate sits 2 percentage points below what was measured; low and high end bracket the measured number.
By their numbers in this assay, from the lowest: compound 1; then compounds 2 and 3 (each within the scatter of the next).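

In this assay, the result shows a number 2 percentage points higher from compound 2 to compound 3 (within the scatter), so at this saturated chain carbon, trifluoromethyl and fluoromethyl cannot be told apart on this read-out. The second new comparison gives a number 77 percentage points higher from compound 1 to compound 3 (beyond the scatter), which means that the large gain over methyl is no longer tied to fluoromethyl alone. Two fluorinated groups at this place now stand well clear of methyl, although the top of the percent-remaining scale leaves little room to separate them.

Still open, from the compounds shown here alone, is whether a group without fluorine at this place, such as methoxymethyl or a longer chain like ethyl, would remain at this level in this assay, or would fall back towards compound 1. No measurement at hand gives a cause for the gain seen with either fluorinated group.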